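Chloro for Bromo in a Small Cytotoxicity Series

The compounds below may be only part of what the source reports. "The series", "measured", "known", "first", "only" and "open" are said of these compounds alone.

Three compounds were measured in a functional assay on MDA-MB-468 cells (Homo sapiens) for cytotoxicity, read by MTT assay, with a stated time of 48 h; on this read-out lower numbers stand for stronger inhibition and higher numbers for weaker inhibition:

Compound 1, `O=C(COc1ccc(Cl)cc1)Nc1nc(-c2ccc(Br)cc2)cs1`, gives 52100 nM.
Compound 2, `O=C(COc1ccc(Cl)cc1)Nc1nc(-c2ccc(Cl)cc2)cs1`, gives 55500 nM.
Compound 3, `Cc1ccc(OCC(=O)Nc2nc(-c3ccc(Br)cc3)cs2)cc1`, gives 44900 nM.

Compound 4, `Cc1ccc(OCC(=O)Nc2nc(-c3ccc(Cl)cc3)cs2)cc1`, is not yet measured. It differs from compound 3 by chloro in place of bromo on an aromatic carbon. The same change, (chloro in place of bromo on an aromatic carbon), was made from compound 1 to compound 2, and there it gave a 1.1-fold higher number from compound 1 to compound 2 (0.03 log units; within the scatter). The two cores differ by methyl in place of chloro on an aromatic carbon, a change that gave a 1.2-fold lower number from compound 1 to compound 3 (0.06 log units; within the scatter). The place of the change is the same in both pairs, so a step of similar size is expected, a 1.1-fold higher number from compound 3 to compound 4 (0.03 log units; within the scatter), resting on compound 2 and a 1.1-fold higher number from compound 1 to compound 2 (0.03 log units; within the scatter). Compound 4 is therefore estimated at 48000 nM, expected to fall between 25000 nM and 90000 nM.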

Compound 4, half-maximal inhibitory concentration: 50900 nM
The estimate for compound 4 lay 1.1-fold (0.03 log units) below the measured number, within the range that was stated.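

In this assay, chloro in place of bromo gave a 1.1-fold higher number from compound 3 to compound 4 (0.05 log units; within the scatter), and this step carried over from one core to the other: the same change on two cores in this assay, a 1.1-fold higher number (0.03 log units; within the scatter) from compound 1 to compound 2 and a 1.1-fold higher number (0.05 log units; within the scatter) from compound 3 to compound 4, 1.1-fold (0.03 log units) apart, within the scatter of two such steps. Methyl in place of chloro gave a 1.1-fold lower number from compound 2 to compound 4 (0.04 log units; within the scatter), and it carried over in the same way: the same change on two cores in this assay, a 1.2-fold lower number (0.06 log units; within the scatter) from compound 1 to compound 3 and a 1.1-fold lower number (0.04 log units; within the scatter) from compound 2 to compound 4, 1.1-fold (0.03 log units) apart, within the scatter of two such steps. All of these steps lie within the scatter, so the four compounds show that neither change measurably moved the number on either core, but not that a step of larger size would carry over between cores.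

The compounds shown leave open what an amine, a carboxylic acid or a longer chain would give in place of the bromo or the methyl. They also leave open whether any such group would produce a step beyond the scatter.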